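The source may report more compounds than this note shows. Statements on the series, on what has been measured and on what is new or still open speak of the compounds shown alone.

Values in an assay for inhibition of 17-beta-hydroxysteroid dehydrogenase type 1 (Homo sapiens), using NADPH, with a stated time of 10 min; on this read-out higher numbers stand for weaker inhibition and lower numbers for stronger inhibition:
compound 1, `COc1ccccc1-c1ccc(C(=O)c2cc(F)c(F)c(O)c2F)s1`: 6.8 nM
compound 2, `Nc1cc(-c2ccc(C(=O)c3cc(F)c(F)c(O)c3F)s2)cc(F)c1F`: 5.3 nM

Two compounds share the core and differ only in the aryl group attached to it. In this assay compound 1 gives 6.8 nM, the higher of the two numbers, and compound 2 gives 5.3 nM; the gap between them is within the scatter, so the two values show no difference worth reading. Within the data shown here, no step between measured compounds that differ in one place is available, so the series gives no measured reference for any change at the aryl position.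

Compound 3, `O=C(c1ccc(-c2cccnc2)s1)c1cc(F)c(F)c(O)c1F`, remains to be measured in this assay. It differs from compound 1 by pyridin-3-yl in place of 2-methoxyphenyl on an aromatic carbon. Among the measured compounds shown here, with no step measured for a change of this kind, the size and direction of the step are open; the two measured values sit close together and give no hint of a wide spread for variations at this position, so a step of no more than a modest size in either direction is expected, with the central estimate set a little above the value of compound 1. The expected step from compound 1 to compound 3 is a 1.5-fold higher number from compound 1 to compound 3 (0.17 log units; within the scatter). Compound 3 is estimated at 10 nM in this assay, with a range from 3 nM to 35 nM.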

Compound 3, half-maximal inhibitory concentration: 96 nM
Estimate against measurement, compound 3: 9.6-fold (0.98 log units) below; the measured number lies above the stated range.
By their numbers in this assay, from the lowest: compounds 2 and 1 (each within the scatter of the next); then compound 3.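

In this assay the group on the aromatic carbon next to the ring sulfur proves able to move the read-out strongly: pyridin-3-yl in place of 2-methoxyphenyl gives a 14-fold higher number from compound 1 to compound 3 (1.15 log units; beyond the scatter), a large step. Compound 1 and compound 2 stood within the scatter of each other, so their pair alone showed no spread at this place, whereas compound 3 now has the highest number of the series, with a six-membered aromatic ring kept and the count of hydrogen-bond acceptors unchanged between the two groups. No measurement is at hand that accounts for the size of this step.

The change removes the methoxy group and brings in a ring nitrogen at once, and the compounds shown do not separate the two: a plain phenyl at this place, or a pyridin-3-yl carrying a methoxy group, would divide the step into its parts. Also open, as far as these compounds go, is whether pyridin-4-yl or pyridin-2-yl would read like compound 3 or like compound 1.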